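Nitro for methoxy on the aryl ring of the thiazolidinone series

This account rests on a few compounds, and the source may have more. Where it says the series, first, only, none or still open, it means among the compounds named here.

Measured so far:
compound 1 `O=C1CSC(c2c(Cl)cccc2Cl)N1CCN1CCCCC1`: 32%
compound 2 `COc1ccccc1C1SCC(=O)N1CCN1CCCCC1`: 67%

Compound 2 gives the highest of the two numbers in an ADME assay on Vero cells (Chlorocebus sabaeus) for cytotoxicity, read by neutral red uptake, tested at 394 ug/mL; on this read-out higher numbers stand for a weaker effect at the one concentration tested and lower numbers for a stronger effect; its nearest neighbour, compound 1, sits well beyond the scatter, lower. Compound 3 `O=C1CSC(c2ccccc2[N+](=O)[O-])N1CCN1CCCCC1` differs from compound 2 by nitro in place of methoxy on an aromatic carbon. Among the measured compounds shown here, no step between measured compounds is directly comparable, so the expected size is uncertain: a moderate downward step, a number 17 percentage points lower from compound 2 to compound 3 (beyond the scatter), is estimated, since compound 1 shows 32% and compound 2 shows 67%. Compound 3 is estimated at 50%, within 25% to 78%.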

Compound 3, a percentage reported as activity, at one concentration (the size of the read-out at that concentration, not a potency): 100%
Beside the measured number, compound 3's estimate is 50 percentage points below it; the measured number lies above the stated range.
By their numbers in this assay, from the lowest: compound 1; then compound 2; then compound 3.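

Within this assay the swap of nitro for methoxy on an aromatic carbon, ortho to a large group, gives a number 33 percentage points higher from compound 2 to compound 3 (beyond the scatter) and so a weaker effect at the one concentration tested. Among the compounds shown here, this is the first step that changes one place only, and it shows that the read-out is sensitive to the group on this carbon.

As far as these compounds go, whether an amine or a carboxylic acid on the same carbon would move the read-out in the same direction stays open. No measurement at hand bears on why the step arises.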